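A few compounds are considered here, and "the series" means these few. Any claim that something is new, unique, unknown or untested is made for them only; others in the source may bear on it.

Compound 1 `COc1ccc(N)c(C2=NN(C(=O)C3CCC3)C(C)(C)S2)c1` and compound 2 `COc1ccc(N)c(C2=NN(C(=O)C3CCCC3)C(C)(C)S2)c1` share one core, while compound 3 `CC1(C)SC(c2cc(Cl)ccc2N)=NN1C(=O)C1CCC1` and compound 4 `CC1(C)SC(c2cc(Cl)ccc2N)=NN1C(=O)C1CCCC1` carry another; the two cores differ by chloro in place of methoxy on an aromatic carbon. In an assay on isolated protein for inhibition of Nitric oxide synthase, inducible (Homo sapiens), read by scintillation counting, with a stated time of 30 min, tested at 50 uM (on this read-out lower numbers stand for less inhibition and higher numbers for more inhibition at the one concentration tested (going by the name of the read-out)), compound 1 gives 57.8%, compound 2 gives 65%, and compound 3 gives -4.65%. Changing the core made a number 62.5 percentage points lower from compound 1 to compound 3 (beyond the scatter). Between compounds 1 and 2 the change is cyclopentyl in place of cyclobutyl on a carbonyl carbon. Measured, that change made a number 7.2 percentage points higher from compound 1 to compound 2 (within the scatter). Compound 4 stands to compound 3 as compound 2 stands to compound 1: the change is cyclopentyl in place of cyclobutyl on a carbonyl carbon, the same change at the same place. Compound 4 has not yet been measured in this assay. A step of a number 6.7 percentage points higher from compound 3 to compound 4 (within the scatter) is expected, because the same change earlier made a number 7.2 percentage points higher from compound 1 to compound 2 (within the scatter). For compound 4 the estimated result is 2%, expected to fall between -12% and 16%.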

Compound 4, a percentage reported as inhibition, at one concentration (the size of the read-out at that concentration, not a potency): 21.3%
For compound 4 the middle estimate is 19.3 percentage points below the measured one, outside the stated range (above it).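

Cyclopentyl in place of cyclobutyl gave a number 26 percentage points higher from compound 3 to compound 4 (beyond the scatter), so the size of this step did not carry over from the methoxy core to the chloro core: the same change on two cores in this assay, a number 7.2 percentage points higher (within the scatter) from compound 1 to compound 2 and a number 26 percentage points higher (beyond the scatter) from compound 3 to compound 4, 18.8 percentage points apart, beyond the scatter of two such steps Chloro in place of methoxy gave a number 43.7 percentage points lower from compound 2 to compound 4 (beyond the scatter), a drop on both cyclobutyl and cyclopentyl compounds, but not one of a fixed size: the same change on two cores in this assay, a number 62.5 percentage points lower (beyond the scatter) from compound 1 to compound 3 and a number 43.7 percentage points lower (beyond the scatter) from compound 2 to compound 4, 18.8 percentage points apart, beyond the scatter of two such steps With only these four compounds, this shows that the two changes do not simply add up in this assay, but it does not show why, or how either change would behave on another core.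

The compounds shown leave open how a cyclohexyl group or an open chain such as isopropyl on the carbonyl carbon would fare on each core. They also leave open what fluoro or an amine would do in place of the methoxy or chloro.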